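Fluorophenyl for Methoxyphenyl: Expected Shift in Cell Toxicity

The compounds below may be only part of what the source reports. "The series", "measured", "known", "first", "only" and "open" are said of these compounds alone.

Measured so far:
Compound 1 `CN(C)CCCCOC(=O)Nc1ccc(Cn2nc(-c3cncnc3)c3ccccc3c2=O)cc1`: 65300 nM
Compound 2 `COc1cccc(-c2nn(Cc3ccc(NC(=O)OCCCCN(C)C)cc3)c(=O)c3ccccc23)c1`: 17600 nM

Both compounds were tested in an ADME assay on Huh-7 cells (Homo sapiens) for cytotoxicity, read by MTT assay, with a stated time of 48 h; on this read-out lower numbers stand for higher toxicity in this test and higher numbers for lower toxicity in this test. Compound 1 gives 65300 nM, and compound 2 gives 17600 nM. Within the data shown here, the one step between them is a 3.7-fold lower number from compound 1 to compound 2 (0.57 log units; beyond the scatter). Compound 2 therefore holds the lowest of the two numbers, standing clearly apart from compound 1, and is the more toxic of the pair in this assay.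

Compound 3 `CN(C)CCCCOC(=O)Nc1ccc(Cn2nc(-c3ccccc3F)c3ccccc3c2=O)cc1` differs from compound 2 in one place: 2-fluorophenyl in place of 3-methoxyphenyl on an aromatic carbon. Among the measured compounds shown here, no measured step exchanges one ring of carbon only for another at this position, so there is no direct precedent. For the measured compounds named here, the single known step, a 3.7-fold lower number from compound 1 to compound 2 (0.57 log units; beyond the scatter), shows that changing the group at this position can move the number by a modest amount, though that step involved a different kind of exchange. Compound 3 is therefore estimated to stay near compound 2, with a 1.3-fold higher number from compound 2 to compound 3 (0.10 log units; within the scatter) expected, a step that would not exceed the scatter. Compound 3 is expected to give about 22000 nM, within a range from 8000 nM to 60000 nM.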

Compound 3, half-maximal cytotoxic concentration: 52500 nM
Estimate against measurement, compound 3: 2.4-fold (0.38 log units) below; the measured number falls inside the stated range.
By their numbers in this assay, from the lowest: compound 2; then compounds 3 and 1 (each within the scatter of the next).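

In this assay, exchanging one ring of carbon only for another at this position is enough to shift the result, with a 3.0-fold higher number from compound 2 to compound 3 (0.47 log units; beyond the scatter), so having a carbon-only ring there does not by itself fix the number. The 2-fluorophenyl of compound 3 and the pyrimidin-5-yl of compound 1 cannot be told apart, with a 1.2-fold lower number from compound 1 to compound 3 (0.09 log units; within the scatter), even though their rings differ in kind, and this leaves compound 2, with its 3-methoxyphenyl, as the only one of the three set apart and the most toxic in this test. Nothing available explains why the 3-methoxyphenyl compound stands alone.

Because the step from compound 2 to compound 3 changes both the substituent and its place on the phenyl ring, these compounds cannot show which of the two matters, and a 3-fluorophenyl or a 2-methoxyphenyl group would separate them. From the compounds shown here alone, it also remains open how a plain phenyl ring, or a ring carrying an amine or a carboxylic acid, would compare at this position.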